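The source may report more compounds than this note shows. Statements on the series, on what has been measured and on what is new or still open speak of the compounds shown alone.

In a functional assay on brain (Rattus norvegicus, strain Wistar) for inhibition (on this read-out lower numbers stand for stronger inhibition and higher numbers for weaker inhibition), compound 1 (`CCCCCOc1ccc(-c2c(C)[nH]c(=O)n2C)cc1`) gives 4500 nM and compound 2 (`CCCCCCCOc1ccc(-c2c(C)[nH]c(=O)n2C)cc1`) gives 5700 nM so the two stand within the scatter of each other. The unmeasured compound 3 (`CCCCCCCCCCCCCCCCCCOc1ccc(-c2c(C)[nH]c(=O)n2C)cc1`) differs from compound 2 by undecyl in place of hydrogen on a saturated chain carbon, seven bonds along the chain from an oxygen on an aromatic ring on the chain. Within the data shown here, the one measured step bearing on this is a 1.3-fold higher number from compound 1 to compound 2 (0.10 log units; within the scatter) and it came from a far shorter addition, so it guides only loosely. In this assay a modest move towards a higher number is therefore expected, and the estimated step is a 1.4-fold higher number from compound 2 to compound 3 (0.15 log units; within the scatter) with wide uncertainty. For compound 3 the expected value is 8000 nM with an estimated range of 2500 nM to 30000 nM in this read-out.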

Compound 3, half-maximal inhibitory concentration: > 100000 nM
Compound 3: no number, only a limit; the forecaster's own chance of this, stated with the estimate: 30%; at least 12-fold (1.09 log units) between middle value and limit.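

Compound 1 and compound 2 stand within the scatter of each other, so the earlier pair gave no sign that this saturated chain carbon was sensitive to chain growth, yet undecyl in place of hydrogen there gives an at least 17-fold higher number from compound 2 to compound 3 (1.24 log units; beyond the scatter) in this assay. The chain can therefore not be extended without limit at this place. For compound 3 the value is a limit and not a number: the limit of > 100000 nM in this assay, at which 1 of the 3 values shown sits.

The compounds shown leave open how much longer than in compound 2 the chain can become before inhibition is lost. They also leave open what an amine or a carboxylic acid would give in place of undecyl on this saturated chain carbon.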